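This account rests on a few compounds, and the source may have more. Where it says the series, first, only, none or still open, it means among the compounds named here.

Measured compounds:
- compound 1 `CCCC(=O)c1ccn(-c2ccc3c(c2)B(O)OC3)c1`: in an ADME assay on L929 cells (Mus musculus) for cytotoxicity, read by resazurin assay, with a stated time of 72 h (on this read-out lower numbers stand for stronger inhibition and higher numbers for weaker inhibition), compound 1 gives > 10 ug/mL, a limit of the assay.
- compound 2 `CCCCCC(=O)c1ccn(-c2ccc3c(c2)B(O)OC3)c1`: in this assay compound 2 gives > 10 ug/mL, a limit.
- compound 3 `O=C(c1ccn(-c2ccc3c(c2)B(O)OC3)c1)c1cccs1`: in this assay compound 3 gives > 10 ug/mL, a limit.

Compound 3 therefore stands, like the other two, at the limit of > 10 ug/mL in this assay, at which 3 of the 3 values shown sit; no number separates any of the three from the others. The steps among them are all shut off by that limit: a step that the two limits leave unreadable from compound 1 to compound 2, a step that the two limits leave unreadable from compound 1 to compound 3 and a step that the two limits leave unreadable from compound 2 to compound 3 give no readable size.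

The next change starts from compound 3 and leads to compound 4 `OB1OCc2ccc(-n3ccc(Cc4ccccc4)c3)cc21`: benzyl in place of (thiophen-2-yl)carbonyl on an aromatic carbon. The shared core is kept; only the group on the five-membered ring changes.

The measured steps that touch compound 3, from compound 1 and from compound 2, bear on this change only as far as the limit allows, which is not at all in size. Nothing among the three readings points to a step in this assay that would be seen beyond the scatter, in either direction. Compound 4 is therefore expected to stay at the limit, with a step that the limit leaves unreadable from compound 3 to compound 4 as the estimated step. The estimate for compound 4 is 15 ug/mL, in the range 5 ug/mL to 50 ug/mL.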

Compound 4, half-maximal inhibitory concentration: > 10 ug/mL
Compound 4 ended at the assay's limit; the forecaster's own chance of this, stated with the estimate: 75%; the middle value is on the limit's open side.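

In this assay, for the compounds shown here, compound 4 gives > 10 ug/mL, a limit of the assay, so no step to compound 4 from compound 1, compound 2 or compound 3 can be read. The compounds shown leave open how far apart the four lie in cytotoxicity, and whether any group on the five-membered ring gives a measurable value.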